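A few compounds are considered here, and "the series" means these few. Any claim that something is new, unique, unknown or untested is made for them only; others in the source may bear on it.

Compound 1 `O=C1N/C(=N/c2csc(-c3ccc(Cl)cc3)c2)S/C1=C\c1ccccc1` and compound 2 `O=C1N/C(=N/c2csc(-c3ccc(Cl)cc3)c2)S/C1=C\c1ccc(Br)cc1` share one core and were tested in a functional assay on MDA-MB-231 cells (Homo sapiens) for cytotoxicity, read by MTT assay, with a stated time of 72 h; on this read-out higher numbers stand for weaker inhibition and lower numbers for stronger inhibition. In this assay compound 1 gives 18000 nM, while compound 2 gives 3500 nM. The step of a 5.1-fold lower number from compound 1 to compound 2 (0.71 log units; beyond the scatter) is the only measured one. Compound 3 `O=C1N/C(=N/c2csc(-c3ccc(Cl)cc3)c2)S/C1=C\c1ccc(O)cc1` has "not determined" (no result reported) in this assay, so where it stands cannot be said. Compound 4 `COc1ccc(/C=C2\S/C(=N\c3csc(-c4ccc(Cl)cc4)c3)NC2=O)cc1OC` differs from compound 3 by 3,4-dimethoxyphenyl in place of 4-hydroxyphenyl on a double-bonded chain carbon bound to a double-bonded ring carbon. Among the compounds with values here, the one measured step concerns bromo in place of hydrogen, a different change, so nothing measured bears directly on this one, and neither the size nor the direction of the step from compound 3 can be expected from the data. Compound 4 is therefore estimated only from the span of compounds 1 and 2, at about 8000 nM, within a wide range from 1500 nM to 40000 nM.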

Compound 4, half-maximal inhibitory concentration: 1900 nM
Compound 4: the middle estimate sits 4.2-fold (0.62 log units) above what was measured; the range from low to high includes it.
By their numbers in this assay, from the lowest: compounds 4 and 2 (each within the scatter of the next); then compound 1.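

In this assay, 3,4-dimethoxyphenyl on the double-bonded chain carbon gives a 9.5-fold lower number from compound 1 to compound 4 (0.98 log units; beyond the scatter), so 4-bromophenyl is no longer the only group shown to differ from plain phenyl at this position. Against 4-bromophenyl, it gives a 1.8-fold lower number from compound 2 to compound 4 (0.27 log units; within the scatter), so these two groups cannot be told apart here. Nothing measured here explains either step. The compounds shown leave open where 4-hydroxyphenyl stands, since compound 3 has no result. They also leave open how a phenyl ring carrying an amine or a carboxylic acid would compare at this position.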